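Swapping the Piperazine Tail for an Aniline Tail

A few compounds are considered here, and "the series" means these few. Any claim that something is new, unique, unknown or untested is made for them only; others in the source may bear on it.

Three compounds share one core and differ only in what hangs from a saturated chain carbon bound to an aromatic nitrogen. Compound 1 `Cn1c(N)c(-c2nc3ccccc3[nH]2)c2nc(C#N)c(C#N)nc21` carries just a hydrogen there; in a functional assay on HL-60 cells (Homo sapiens) for antiproliferative activity, read by MTT assay, with a stated time of 48 h (a higher number here means a weaker inhibitor, a lower number a stronger inhibitor), compound 1 gives only a limit, > 50000 nM, the point where the measurement stops (the limit of > 50000 nM in this assay, at which 1 of the 3 values shown sits). Compound 2 `CN1CCN(CCn2c(N)c(-c3nc4ccccc4[nH]3)c3nc(C#N)c(C#N)nc32)CC1` carries a 2-(4-methylpiperazin-1-yl)ethyl chain and in this assay compound 2 gives 4300 nM. Compound 3 `CN1CCN(CCCn2c(N)c(-c3nc4ccccc4[nH]3)c3nc(C#N)c(C#N)nc32)CC1` carries a chain one carbon longer, and compound 3 gives 750 nM. Of the two numbers, compound 2 is the higher one, so the weaker inhibitor. The steps of an at least 11-fold lower number from compound 1 to compound 2 (1.06 log units; beyond the scatter) and an at least 66-fold lower number from compound 1 to compound 3 (1.82 log units; beyond the scatter) are both large, while a 5.7-fold lower number from compound 2 to compound 3 (0.76 log units; beyond the scatter) is modest.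

The unmeasured compound 4 `N#Cc1nc2c(-c3nc4ccccc4[nH]3)c(N)n(CCCNc3ccccc3)c2nc1C#N` differs from compound 2 by anilinomethyl in place of 4-methylpiperazin-1-yl on a saturated chain carbon, two bonds along the chain from an aromatic nitrogen. Cut one bond further out, this gives compound 4 a chain as long as that of compound 3, but ended by an anilino group instead of the piperazine. Lengthening alone gave the modest gain from compound 2 to compound 3, so a gain of similar or smaller size is expected here, the new end group adding uncertainty. Compound 4 is therefore expected to give about 1500 nM, between 300 nM and 8000 nM, an expected step of a 2.9-fold lower number from compound 2 to compound 4 (0.46 log units; beyond the scatter) in this assay.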

Compound 4, half-maximal inhibitory concentration: 6920 nM
Compound 4: middle estimate off by 4.6-fold (0.66 log units), on the low side, and the stated range covers the measured number.
By their numbers in this assay, from the lowest: compound 3; then compounds 2 and 4 (each within the scatter of the next). At a limit, above all of these: compound 1.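

With the chain kept as in compound 3, the end group alone decides a great deal at this position in this assay: anilino in place of 4-methylpiperazin-1-yl gives a 9.2-fold higher number from compound 3 to compound 4 (0.97 log units; beyond the scatter), so the chain that served compound 3 well does not give the same number with every end group. Compound 4 and compound 2 differ in both chain length and end group, yet they cannot be told apart, with a 1.6-fold higher number from compound 2 to compound 4 (0.21 log units; within the scatter), which means the longer chain with an anilino end shows no gain over the shorter chain with the piperazine. A chain without the piperazine still lowers the number relative to the plain methyl of compound 1, with an at least 7.2-fold lower number from compound 1 to compound 4 (0.85 log units; beyond the scatter), but this step rests on a limit for compound 1 and not on a true number: the limit of > 50000 nM in this assay, at which 1 of the 4 values shown sits.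

The compounds shown leave open whether other amines at the end of this chain, such as a morpholine, a piperidine or a dimethylamino group, would behave like the piperazine or like the anilino group. They also leave open how the shorter 2-anilinoethyl chain or a longer 4-anilinobutyl chain would compare with compound 4.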